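The compounds below may be only part of what the source reports. "The series", "measured", "known", "first", "only" and "open" are said of these compounds alone.

Working notes on the series. Compound 1, `C[C@H](NC(=O)Nc1ccccc1C(F)(F)F)c1ccccc1`, in an ADME assay on the whole organism with Oryza sativa as the target, tested at 0.1 uM (a higher number here means a weaker effect of the compound at the concentration tested, a lower number a stronger effect), gives 97%. Compound 2, `C[C@@H](NC(=O)Nc1ccccc1F)c1ccccc1`, in this assay gives 97%, level with compound 1 at the digits reported, the two readings lying within the scatter of one another. Compound 3, `C[C@H](NC(=O)Nc1ccccc1F)c1ccccc1`, has not yet been measured in this assay. The change from compound 2 to compound 3 is the two compounds have the same atoms and bonds and differ only in configuration as drawn: 1 of 1 stereo elements differ; a stereocentre at a saturated chain carbon is drawn R in compound 2 and S in compound 3. Among the compounds with values here, no measured pair in the set isolates such a change on its own, so no step size can be drawn from the data. The expected step is a number 1 percentage points lower from compound 2 to compound 3 (within the scatter), an estimate that stays within the scatter in either direction. Compound 3 is estimated at 96%, from 84% to 100%.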

Compound 3, a percentage reported as activity, at one concentration (the size of the read-out at that concentration, not a potency): 98%
The estimate for compound 3 lay 2 percentage points below the measured number; low and high end bracket the measured number.
By their numbers in this assay, from the lowest: compounds 1, 2 and 3 (each within the scatter of the next).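

In this assay, within the data shown here, inverting the stereocentre at the saturated chain carbon gives a number 1 percentage points higher from compound 2 to compound 3 (within the scatter), the first step for this change alone: the fact that compounds 2 and 3 differ only in the configuration as drawn. Fluoro in place of trifluoromethyl on an aromatic carbon gives a number 1 percentage points higher from compound 1 to compound 3 (within the scatter). Neither change takes the read-out beyond the scatter at the concentration tested.

Going by these compounds, whether a methoxy group or a carboxylic acid on the aromatic carbon would separate from these readings remains open. So does the effect of an amine or a longer chain in place of the methyl group on the stereocentre.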